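The source may hold more compounds than are shown below. What is called first, only, known or untested is meant among the compounds shown, and "the series" means these compounds.

Compound 1 `COc1cc(/C=C/C(=O)c2cccc(-n3cc(-c4ccc(Cl)cc4)[nH]c3=O)c2)cc(OC)c1OC`: 6460 nM
Compound 2 `COc1ccc(-c2cn(-c3cccc(C(=O)/C=C/c4cc(OC)c(OC)c(OC)c4)c3)c(=O)[nH]2)cc1`: 3040 nM

Both compounds were tested in a functional assay on TK-10 cells (Homo sapiens) for inhibition; a higher number here means a weaker inhibitor of growth, a lower number a stronger inhibitor of growth. For the measured compounds named here, compound 2 has the lower of the two numbers, and the only measured step is a 2.1-fold lower number from compound 1 to compound 2 (0.33 log units; beyond the scatter), which arises from methoxy in place of chloro on an aromatic carbon. Compound 3 `COc1cc(/C=C/C(=O)c2cccc(-n3cc(-c4cc(OC)c(OC)c(OC)c4)[nH]c3=O)c2)cc(OC)c1OC` has not yet been measured. It differs from compound 2 in one place: 3,4,5-trimethoxyphenyl in place of 4-methoxyphenyl on an aromatic carbon. Going by the values given here, the measured step is the only guide, and it shows that exchanging the group on this aromatic carbon moves the number only modestly; nothing here tells how the two further methoxy groups act. A step of similar or smaller size is therefore expected in this assay, in either direction, most likely within the scatter. Compound 3 is estimated at 2500 nM, with a range of 800 nM to 8000 nM, which means an expected step of a 1.2-fold lower number from compound 2 to compound 3 (0.08 log units; within the scatter).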

Compound 3, concentration for 50% growth inhibition: 3000 nM
Beside the measured number, compound 3's estimate is 1.2-fold (0.08 log units) below it; the range from low to high includes it.
By their numbers in this assay, from the lowest: compounds 3 and 2 (each within the scatter of the next); then compound 1.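

In this assay the change from 4-methoxyphenyl to 3,4,5-trimethoxyphenyl gives a 1.0-fold lower number from compound 2 to compound 3 (0.01 log units; within the scatter) and so does not separate the two compounds, which means the two further methoxy groups bring no change that can be told from scatter at this position. Replacing 4-chlorophenyl with 3,4,5-trimethoxyphenyl gives a 2.2-fold lower number from compound 1 to compound 3 (0.33 log units; beyond the scatter) and is the same size as a 2.1-fold lower number from compound 1 to compound 2 (0.33 log units; beyond the scatter) when the printed values are compared, so both methoxy-bearing groups stand apart from the 4-chlorophenyl group by a modest step. Nothing measured here gives a reason for this pattern.

The compounds shown leave open how a hydroxy group, an amine or a carboxylic acid on this phenyl ring would act. They also do not tell whether a longer chain on the oxygen in place of methyl would move the number.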